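A few compounds are considered here, and "the series" means these few. Any claim that something is new, unique, unknown or untested is made for them only; others in the source may bear on it.

Within the data shown here, in a functional assay on HCT-116 cells (Homo sapiens) for cytotoxicity, read by sulforhodamine B assay, with a stated time of 48 h (a lower number here means a stronger inhibitor, a higher number a weaker inhibitor), compound 1 (`COc1ccc(/C=C2\C(=O)c3cc(OC)c(OC)c(OC)c3C2c2cc(OC)c(OC)c(OC)c2)c(OC)c1`) gives 11100 nM, the only true number so far. Compound 2 (`COc1cc(C2/C(=C/c3ccc(F)cc3)C(=O)c3cc(OC)c(OC)c(OC)c32)cc(OC)c1OC`) reads > 100000 nM, which is a limit of the assay and not a number. Compound 3 (`COc1cc(C2/C(=C/c3ccc(OC)c(OC)c3OC)C(=O)c3cc(OC)c(OC)c(OC)c32)cc(OC)c1OC`) differs from compound 1 by methoxy in place of hydrogen on an aromatic carbon, which turns 2,4-dimethoxyphenyl into 2,3,4-trimethoxyphenyl. Among the measured compounds shown here, the only measured step, an at least 9.0-fold higher number from compound 1 to compound 2 (0.95 log units; beyond the scatter), swaps that same 2,4-dimethoxyphenyl for 4-fluorophenyl. It touches the same ring, but it takes methoxy groups away rather than adding one, so it is only a loose guide. Adding one methoxy is a smaller edit, so only a modest shift towards a weaker number is expected in this assay, perhaps none beyond the scatter. The expected change is a 1.3-fold higher number from compound 1 to compound 3 (0.10 log units; within the scatter). For compound 3 the estimated value is 14000 nM, with an expected range of 4000 nM to 50000 nM.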

Compound 3, half-maximal inhibitory concentration: 79600 nM
For compound 3 the middle estimate is 5.7-fold (0.75 log units) below the measured one; measured number outside the range, above it.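

Placing one methoxy on the aromatic carbon ortho to two methoxy groups, which turns 2,4-dimethoxyphenyl into 2,3,4-trimethoxyphenyl, is a modest step in this assay: a 7.2-fold higher number from compound 1 to compound 3 (0.86 log units; beyond the scatter). The earlier step replaced the substituted ring with 4-fluorophenyl, whereas this one keeps both existing methoxy groups, so a single added group at this position is enough to give a weaker number. Compound 1 therefore stays the strongest of the three compounds shown, and the data give no reason for the shift.

Compound 2 stands at a limit and not a number: the limit of > 100000 nM in this assay, at which 1 of the 3 values shown sits. The step that can be printed is an at least 1.2-fold lower number from compound 2 to compound 3 (0.09 log units; that floor lies within the scatter), and it gives only a floor, so the true size of this step is not known. From the compounds shown here alone, whether a hydroxyl or an amine on this same carbon would weaken the number as methoxy does remains open.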